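Working notes on compound 4 and its measured neighbours

This account rests on a few compounds, and the source may have more. Where it says the series, first, only, none or still open, it means among the compounds named here.

Of the compounds shown here, three have been measured in a functional assay on SNB-19 cells (Homo sapiens) for inhibition, read by sulforhodamine B assay, with a stated time of 48 h, tested at 0.1 uM; a higher number here means a weaker effect of the compound at the concentration tested, a lower number a stronger effect. Compound 1 `O=C(Nc1cccc(-n2cc(-c3ccncc3)c(-c3cc(O)cc(Cl)c3)n2)c1)Nc1ccc(Cl)c(C(F)(F)F)c1` gives 95%, compound 2 `COc1cc(Cl)cc(-c2nn(-c3cccc(NC(=O)Nc4ccc(Cl)c(C(F)(F)F)c4)c3)cc2-c2ccncc2)c1` gives 95% and compound 3 `COc1cc(Cl)cc(-c2nn(-c3cccc(NC(=O)Nc4cc(C(F)(F)F)cc(C(F)(F)F)c4)c3)cc2-c2ccncc2)c1` gives 87%. Compound 2 stands level with compound 1, the two together the highest of the three numbers, and compound 3 sits slightly lower, within the scatter. Among the measured compounds shown here, the only step between single-point neighbours, no change at the digits printed from compound 1 to compound 2 (within the scatter), concerns methyl in place of hydrogen on an oxygen on an aromatic ring. Compound 4 `COc1cc(Cl)cc(-c2nn(-c3cccc(NC(=O)c4cccc(C(F)(F)F)c4)c3)cc2-c2ccncc2)c1` differs from compound 2 as follows: 3-(trifluoromethyl)phenyl in place of (4-chloro-3-(trifluoromethyl)phenyl)amino on a carbonyl carbon. For the measured compounds named here, no measured step touches the carbonyl carbon or what hangs from it, so that earlier step gives no direct guide, and the default expectation is no change beyond the scatter. Compound 4 is therefore estimated at 93%, within 75% to 104%. The expected step is a number 2 percentage points lower from compound 2 to compound 4 (within the scatter).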

Compound 4, a percentage reported as activity, at one concentration (the size of the read-out at that concentration, not a potency): 97%
Estimate against measurement, compound 4: 4 percentage points below; the range from low to high includes it.
By their numbers in this assay, from the lowest: compounds 3, 1, 2 and 4 (each within the scatter of the next).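

Among the compounds shown here, this is the first measured step at the carbonyl carbon: in this assay, the change gives a number 2 percentage points higher from compound 2 to compound 4 (within the scatter). The read-out therefore does not register the loss of the amino link, with its hydrogen-bond donor, together with the chlorine, although all values remain on the weak-effect side at this single concentration. No evidence bears on why this exchange leaves the number within the scatter.

The chlorine and the amino link remain unseparated, since they change together. Also open, as far as these compounds go, is whether a morpholine or a longer alkyl chain on the carbonyl carbon would move the read-out beyond the scatter.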